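Halogen swap on the pendant phenyl ring

A few compounds are considered here, and "the series" means these few. Any claim that something is new, unique, unknown or untested is made for them only; others in the source may bear on it.

compound 1 `CCOC(=O)C1=C(C)NC(C)=C(C(=O)OCC)C1c1c(-c2ccc(F)cc2)nc2sccn12`: 64 nM
compound 2 `CCOC(=O)C1=C(C)NC(C)=C(C(=O)OCC)C1c1c(-c2ccc(F)c(F)c2)nc2sccn12`: 21 nM

In an ADME assay on Left cardiac atrium (Cavia porcellus) (on this read-out lower numbers stand for an effect already at smaller amounts and higher numbers for an effect only at larger amounts of compound), compound 1 gives 64 nM and compound 2 gives 21 nM. Within the data shown here, compound 2 thus holds the lowest of the two numbers measured so far, with compound 1 as its only neighbour. Among the measured compounds shown here, the single measured step is a 3.0-fold lower number from compound 1 to compound 2 (0.48 log units; beyond the scatter), a modest change for a single added fluorine.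

Compound 3 `CCOC(=O)C1=C(C)NC(C)=C(C(=O)OCC)C1c1c(-c2ccc(Cl)cc2)nc2sccn12` differs from compound 2 by 4-chlorophenyl in place of 3,4-difluorophenyl on an aromatic carbon. For the measured compounds named here, this change removes the second fluorine that the measured step introduced, so its reversal suggests a rise in number, while the exchange of fluoro for chloro on the same phenyl ring has no measured counterpart here. The expected step is therefore a 2.4-fold higher number from compound 2 to compound 3 (0.38 log units; beyond the scatter), landing compound 3 near compound 1 with a wide range. Compound 3 is estimated at 50 nM, between 15 nM and 170 nM.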

Compound 3, half-maximal effective concentration: 97 nM
Compound 3: middle estimate off by 1.9-fold (0.29 log units), on the low side, and the stated range covers the measured number.
By their numbers in this assay, from the lowest: compound 2; then compounds 1 and 3 (each within the scatter of the next).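

In this assay, among these compounds, replacing 3,4-difluorophenyl with 4-chlorophenyl gives a 4.6-fold higher number from compound 2 to compound 3 (0.66 log units; beyond the scatter) and shows that this change on the aromatic carbon of the five-membered ring is larger than the single fluorine step alone. Chloro in place of fluoro gives a 1.5-fold higher number from compound 1 to compound 3 (0.18 log units; within the scatter) and so separates neither of the two compounds with one halogen from the other. Among the three compounds, only the one carrying 3,4-difluorophenyl stands apart, and nothing at hand accounts for this.

The compounds shown leave open whether 3,4-dichlorophenyl would match 3,4-difluorophenyl or fall with the compounds carrying one halogen. They also leave open what a methoxy group or an amine on the same phenyl ring would do to this number.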